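Shortening the amine side chain in a lactam series

The compounds below may be only part of what the source reports. "The series", "measured", "known", "first", "only" and "open" are said of these compounds alone.

Compound 1 `CC(C)[C@H](O)CNC(C)(C)CC(=O)N[C@@H]1CCc2ccccc2N(Cc2ccc(-c3ccccc3-c3nn[nH]n3)cc2)C1=O` and compound 2 `C[C@H](O)CNC(C)(C)C(=O)N[C@@H]1CCc2ccccc2N(Cc2ccc(-c3ccccc3-c3nn[nH]n3)cc2)C1=O` share a core and differ only in the chain on the amine nitrogen. In a functional assay (Pituitary gland cell) with Rattus norvegicus as the target (a higher number here means that more compound is needed for the effect, a lower number that less compound is needed), compound 1 gives 1000 nM, the higher of the two numbers shown, while compound 2 gives 700 nM; the step of a 1.4-fold lower number from compound 1 to compound 2 (0.15 log units; within the scatter) lies within the scatter. Compound 3 `CCCNC(C)(C)CC(=O)N[C@@H]1CCc2ccccc2N(Cc2ccc(-c3ccccc3-c3nn[nH]n3)cc2)C1=O` keeps the core of compound 1 and changes the same region: ethyl in place of 1-hydroxy-2-methylpropyl on a saturated chain carbon bound to an amine nitrogen, so that the 2-hydroxy-3-methylbutyl group becomes propyl. Within the data shown here, the only measured step that bears on this region, from compound 1 to compound 2, was small and within the scatter, so a change of similar kind is expected to move the number little. For compound 3 the expected step is a 1.3-fold higher number from compound 1 to compound 3 (0.11 log units; within the scatter), with no direction clearly beyond the scatter. Compound 3 is therefore estimated at 1300 nM, in a range from 500 nM to 3500 nM.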

Compound 3, concentration for half-maximal effect: 50 nM
Compound 3: the middle estimate sits 26-fold (1.41 log units) above what was measured; the measured number lies below the stated range.
By their numbers in this assay, from the lowest: compound 3; then compounds 2 and 1 (each within the scatter of the next).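

In this assay, this position proves far more sensitive than the earlier pair suggested: ethyl in place of 1-hydroxy-2-methylpropyl on a saturated chain carbon bound to an amine nitrogen gives a 20-fold lower number from compound 1 to compound 3 (1.30 log units; beyond the scatter), a large step where the earlier one stayed within the scatter. The propyl chain also stands apart from the shorter hydroxylated side chain, with a 14-fold lower number from compound 2 to compound 3 (1.15 log units; beyond the scatter), for 2-methyl-2-(propylamino)propyl in place of 1-((2-hydroxypropyl)amino)-1-methylethyl on a carbonyl carbon. Nothing available here explains why these steps are so large.

The compounds shown leave open whether the step follows from the removal of the hydroxyl or from the shortening of the chain, as both change together. A 3-methylbutyl group on the amine nitrogen, which keeps the carbon chain without the hydroxyl, would separate the two.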